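Shortening the amide arm of compound 3

A few compounds are considered here, and "the series" means these few. Any claim that something is new, unique, unknown or untested is made for them only; others in the source may bear on it.

The three measured compounds share one core bearing a trifluoromethyl group and differ only in the substituent on an aromatic nitrogen. Compound 1 `NCc1ccc(-n2cc(-c3ccc4cc[nH]c4c3)c(C(F)(F)F)n2)cc1` carries a 4-(aminomethyl)phenyl group there. In an assay on isolated protein for inhibition of thyroid peroxidase (Homo sapiens) (on this read-out lower numbers stand for stronger inhibition and higher numbers for weaker inhibition), compound 1 gives only a limit, > 30000 nM. Compound 2 `NCCCCn1cc(-c2ccc3cc[nH]c3c2)c(C(F)(F)F)n1` carries a 4-aminobutyl chain instead. In this assay compound 2 likewise reaches only the limit > 30000 nM. Compound 3 `NC(=O)CCn1cc(-c2ccc3cc[nH]c3c2)c(C(F)(F)F)n1` carries a 2-carbamoylethyl chain. In this assay compound 3 again gives only the limit > 30000 nM. The steps a step that the two limits leave unreadable from compound 1 to compound 2, a step that the two limits leave unreadable from compound 1 to compound 3 and a step that the two limits leave unreadable from compound 2 to compound 3 cannot be sized because every value sits at the same limit (the limit of > 30000 nM in this assay, at which 3 of the 3 values shown sit). Compound 3 therefore stands nowhere distinct among the numbers shown; all three compounds remain undetermined at the ceiling of this assay.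

Compound 4 `NC(=O)Cn1cc(-c2ccc3cc[nH]c3c2)c(C(F)(F)F)n1` shortens the arm of compound 3 by one carbon: carbamoyl in place of carbamoylmethyl on a saturated chain carbon bound to an aromatic nitrogen. Going by the values given here, no measured step bears directly on this change, and the steps that exist give no readable size. The estimated step of a number no higher from compound 3 to compound 4 (the limit leaves the size open) is expected to stay within the scatter. Compound 4 is therefore expected to give 30000 nM, within a range of 6000 nM to 100000 nM, most probably reported once more as a limit rather than a number.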

Compound 4, half-maximal inhibitory concentration: > 30000 nM
Compound 4: no number, only a limit; the forecaster's own chance of this, stated with the estimate: 80%; the middle value sits exactly at the limit.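

Going by these compounds alone, with compound 4 added, no step among compound 1, compound 2, compound 3 and compound 4 can be read in this assay, because each value is a limit and not a number: the limit of > 30000 nM in this assay, at which 4 of the 4 values shown sit. The compounds shown leave open how strongly any of them inhibits in this assay, and whether changing the substituent on the aromatic nitrogen alters that inhibition.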